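The compounds below may be only part of what the source reports. "The series", "measured", "known", "first", "only" and "open" are said of these compounds alone.

Measured compounds:
Compound 1, `CCCCCCNC(=S)N/N=C1\C(=O)Nc2ccc([N+](=O)[O-])cc21`, gives 25%.
Compound 2, `C=CCNC(=S)N/N=C1\C(=O)Nc2ccc([N+](=O)[O-])cc21`, gives 25%.

The two measured compounds share one core and differ only in the group on the thiocarbonyl nitrogen. In a functional assay on the whole organism for inhibition, with Lemna aequinoctialis as the target, tested at 10 ug/mL (a lower number here means less inhibition of growth, a higher number more inhibition of growth at the concentration tested), compound 1 gives 25%, and compound 2 gives 25%. Going by the values given here, the one measured step, no change at the digits printed from compound 1 to compound 2 (within the scatter), shows that exchanging pentyl for vinyl on the saturated chain carbon bound to the amide-type nitrogen leaves the read-out where it was. Compound 2 therefore stands level with compound 1 in this assay, and neither can be called the more active.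

Compound 3, `Cc1cccc(NC(=S)N/N=C2\C(=O)Nc3ccc([N+](=O)[O-])cc32)c1`, is not yet measured. It differs from compound 2 as follows: 3-methylphenyl in place of allyl on an amide-type nitrogen. The measured step from compound 1 to compound 2 bears on it only loosely, since that step swapped one chain for another, whereas here allyl gives way to 3-methylphenyl. Among the compounds with values here, no measured pair shows the effect of putting a six-membered aromatic ring at this position, so the data give no direction for the change. The step that compound 3 is expected to show is a number 5 percentage points higher from compound 2 to compound 3 (within the scatter), no larger than the scatter. Compound 3 is estimated at 30%, in the range 10% to 55%.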

Compound 3, percent growth inhibition at one concentration: 10%
Compound 3: the middle estimate sits 20 percentage points above what was measured, and the stated range covers the measured number.
By their numbers in this assay, from the lowest: compound 3; then compounds 1 and 2 (each within the scatter of the next).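

In this assay, the group on the amide-type nitrogen now proves able to move the read-out: 3-methylphenyl in place of allyl gives a number 15 percentage points lower from compound 2 to compound 3 (beyond the scatter), and 3-methylphenyl in place of hexyl gives a number 15 percentage points lower from compound 1 to compound 3 (beyond the scatter). The earlier pair had only shown two open chains reading level, so this is the first change at this position that lies beyond the scatter, and it runs toward less inhibition of growth. Nothing available explains why this replacement lowers the number.

As far as these compounds go, whether the lower reading belongs to the aromatic ring itself or to its methyl stays open, and a plain phenyl, a cyclohexyl or a benzyl on this nitrogen would be the groups to separate those readings. Also open, from the compounds shown here alone, is whether the level reading of compound 1 and compound 2 would hold for a chain carrying an amine or a carboxylic acid, and whether 3-methylphenyl would give a step of the same direction on a core with a chlorine in place of the nitro group.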